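Swapping the Amine Side Chain on Compound 1

The source may hold more compounds than are shown below. What is called first, only, known or untested is meant among the compounds shown, and "the series" means these compounds.

The three measured compounds share one core and differ in the amine group and in the aryl amide. Compound 1 `Cc1cc(NCCN(C)C)nc2ccc(NC(=O)c3ccc(Cl)c(Cl)c3)cc12` gives 2550 nM in a functional assay on MCF7 cells (Homo sapiens) for antiproliferative activity, read by MTT assay, with a stated time of 72 h (a higher number here means a weaker inhibitor, a lower number a stronger inhibitor), the lowest number of the three. Compound 2 `CCN1CCN(c2cc(C)c3cc(NC(=O)c4cccnc4)ccc3n2)CC1` gives 26600 nM, and compound 3 `CCN1CCN(c2cc(C)c3cc(NC(=O)c4ccc(F)c(F)c4)ccc3n2)CC1` gives 5230 nM; both stand beyond the scatter above compound 1, with compound 3 the nearer of the two.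

Within the data shown here, the only step measured in one place is a 5.1-fold lower number from compound 2 to compound 3 (0.71 log units; beyond the scatter). That pair differs in the aryl amide alone. Compound 4 `Cc1cc(N2CCN(C)CC2)nc2ccc(NC(=O)c3ccc(Cl)c(Cl)c3)cc12` changes a different part of compound 1: 4-methylpiperazin-1-yl in place of (2-(dimethylamino)ethyl)amino on an aromatic carbon. Among the measured compounds shown here, no measured pair isolates this amine change, since compound 3 carries a ring amine together with a different aryl amide than compound 1. The data therefore give no direct guide, and compound 3, which holds a related ring amine, stays within a modest distance of compound 1.

Compound 4 is thus expected to stay close to compound 1, with an estimated step of a 1.3-fold higher number from compound 1 to compound 4 (0.10 log units; within the scatter). For compound 4 an estimate of 3200 nM is proposed, ranging from 1200 nM to 8500 nM.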

Compound 4, half-maximal inhibitory concentration: 3000 nM
For compound 4 the middle estimate is 1.1-fold (0.03 log units) above the measured one; the range from low to high includes it.
By their numbers in this assay, from the lowest: compounds 1, 4 and 3 (each within the scatter of the next, the first and the last beyond it); then compound 2.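

The exchange of (2-(dimethylamino)ethyl)amino for 4-methylpiperazin-1-yl on the aromatic carbon next to the ring nitrogen gives a 1.2-fold higher number from compound 1 to compound 4 (0.07 log units; within the scatter) in this assay. Among these compounds, this is the first pair that isolates the amine at this position, which the earlier compounds could not do because each of them differed from compound 1 in the aryl amide as well. Within this single pair, the open chain with its hydrogen-bond donor and the six-membered non-aromatic ring without one cannot be told apart, and no measured property is at hand to explain this result.

The compounds shown leave open whether this position accepts other amines equally well, such as a morpholin-4-yl ring, which keeps the ring but holds an oxygen in place of the second nitrogen, or the longer chain (3-(dimethylamino)propyl)amino. On these data alone, it also remains open whether the two amines would still read alike when paired with the pyridin-3-yl amide of compound 2 or the 3,4-difluorophenyl amide of compound 3, so the result cannot yet be extended beyond this one aryl amide.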